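The source may hold more compounds than are shown below. What is called first, only, known or untested is meant among the compounds shown, and "the series" means these compounds.

Values measured so far in a functional assay on Daoy cells (Homo sapiens) for antiproliferative activity, read by trypan blue exclusion and crystal violet staining, with a stated time of 72 h (on this read-out higher numbers stand for weaker inhibition and lower numbers for stronger inhibition), are these:

Compound 1 `CCCC(=O)NC(c1ccccc1)c1cc(Cl)c2cccnc2c1O` gives 110 nM
Compound 2 `CCCC(=O)NC(c1ccc(N(CC)CC)cc1)c1cc(Cl)c2cccnc2c1O` gives 100 nM
Compound 3 `CCCC(=O)NC(c1ccccc1Cl)c1cc(Cl)c2cccnc2c1O` gives 100 nM

Compound 3 stands level with compound 2, and compound 1 lies within the scatter of both. Compound 4 `CCCC(=O)NC(c1ccc(C(C)C)cc1)c1cc(Cl)c2cccnc2c1O` has not yet been measured in this assay. It carries 4-isopropylphenyl in place of 2-chlorophenyl on a saturated chain carbon bound to an amide-type nitrogen and an aromatic carbon, and the counted difference reads (4-isopropylphenyl in place of 2-chlorophenyl on a saturated chain carbon bound to an amide-type nitrogen and an aromatic carbon). Among the compounds with values here, two measured steps bear on this change. Diethylamino in place of hydrogen on an aromatic carbon gave a 1.1-fold lower number from compound 1 to compound 2 (0.04 log units; within the scatter), and chloro in place of hydrogen on an aromatic carbon gave a 1.1-fold lower number from compound 1 to compound 3 (0.04 log units; within the scatter). Within the data shown here, both steps are small, and no measured compound carries 4-isopropylphenyl itself. As far as these compounds go, a change beyond the scatter is therefore not expected, and the direction stays open. The estimated step is no change at the digits printed from compound 3 to compound 4 (within the scatter). Compound 4 is expected at 100 nM, within an estimated range of 50 nM to 200 nM.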

Compound 4, half-maximal inhibitory concentration: 90 nM
The estimate for compound 4 lay 1.1-fold (0.05 log units) above the measured number; low and high end bracket the measured number.
By their numbers in this assay, from the lowest: compounds 4, 2, 3 and 1 (each within the scatter of the next).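

In this assay, 4-isopropylphenyl in place of 2-chlorophenyl at this saturated chain carbon gave a 1.1-fold lower number from compound 3 to compound 4 (0.05 log units; within the scatter) and isopropyl in place of diethylamino gave a 1.1-fold lower number from compound 2 to compound 4 (0.05 log units; within the scatter) while isopropyl in place of hydrogen gave a 1.2-fold lower number from compound 1 to compound 4 (0.09 log units; within the scatter) as the third reading. The earlier substituents on this aromatic ring carried chlorine or nitrogen, whereas isopropyl is built of carbon only, and this change too stays within the scatter. Across the four compounds, then, hydrogen, chloro, diethylamino and isopropyl on this ring cannot be told apart in this read-out.

As far as these compounds go, whether a carboxylic acid or a primary amine in place of isopropyl would carry the number beyond the scatter stays open. So does the effect of a longer chain on the amide carbonyl, and nothing given here offers an explanation for the closeness of these numbers.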